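The compounds below may be only part of what the source reports. "The series", "measured", "known", "first", "only" and "open" are said of these compounds alone.

Compound 1 `CC(C)(C)C(=O)OCO[P@@]1(=O)OCC(C)(C)[C@H](C(=O)NCCC(=O)O)O1` gives > 1 h in an ADME assay on blood (Homo sapiens) for pharmacokinetics (a lower number here means that the compound disappears faster, a higher number that the compound lasts longer), which is a limit of the assay rather than a number.
Compound 2 `COC(=O)CCNC(=O)[C@@H]1O[P@@](=O)(OCOC(=O)c2ccns2)OCC1(C)C` gives < 0.16 h in this assay, again a limit.
Compound 3 `CC(C)(C)C(=O)OCO[P@@]1(=O)OCC(C)(C)[C@H](C(=O)NCCC(=O)OCCc2ccccn2)O1` gives < 0.16 h in this assay, also a limit.

Among the measured compounds shown here, compound 3 therefore stands at the fast end of what has been measured: its value is only a limit, and two of the three values shown sit there (the limit of < 0.16 h in this assay, at which 2 of the 3 values shown sit), while the one remaining value sits at the opposite limit (the limit of > 1 h in this assay, at which 1 of the 3 values shown sits). For the measured compounds named here, the single step measured between compounds that differ in one place is an at least 6.2-fold lower number from compound 1 to compound 3 (0.79 log units; beyond the scatter), a change of 2-(pyridin-2-yl)ethyl in place of hydrogen on an oxygen next to a carbonyl group.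

Compound 4 `CCOC(=O)CCNC(=O)[C@@H]1O[P@@](=O)(OCOC(=O)C(C)(C)C)OCC1(C)C` differs from compound 3 by hydrogen in place of pyridin-2-yl on a saturated chain carbon, two bonds along the chain from an oxygen next to a carbonyl group. Going by the values given here, no measured step covers this exact change, but compound 2, which likewise carries a small group rather than hydrogen at the corresponding end of the chain, also sits at the lower limit, as does compound 3. The expectation for the step that the limit leaves unreadable from compound 3 to compound 4 is thus no change beyond the scatter. Compound 4 is estimated at 0.12 h, with a range from 0.04 h to 0.4 h, most likely reported again only as a limit.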

Compound 4, half-life: 0.28 h
Beside the measured number, compound 4's estimate is 2.3-fold (0.37 log units) below it, within the range that was stated.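

Among the compounds shown here, compound 4 gives 0.28 h in this assay, the first value in this set that is a number and not a limit, so a plain ethyl on the oxygen next to a carbonyl group now has a readable half-life. Taking the pyridin-2-yl away from the saturated chain carbon gives an at least 1.7-fold higher number from compound 3 to compound 4 (0.24 log units; that floor lies within the scatter); that step starts from a limit and its true size stays unknown, so these compounds neither show that the pyridin-2-yl shortens the half-life nor rule it out. The ethyl alone, with no ring on the chain, is enough for an at least 3.5-fold lower number from compound 1 to compound 4 (0.55 log units; beyond the scatter), which also starts from a limit but is already beyond the scatter, and so the drop seen in an at least 6.2-fold lower number from compound 1 to compound 3 (0.79 log units; beyond the scatter) does not need the pyridin-2-yl.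

The compounds shown leave open how a longer chain such as butyl, or an amine at the end of the ethyl chain, would behave on this oxygen in this assay. From the compounds shown here alone, compound 2 differs from compound 4 in more than one place and stays outside this comparison, so the effect of a methyl alone on this oxygen also remains open.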